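Nitro for chloro on the pendant phenyl ring

A few compounds are considered here, and "the series" means these few. Any claim that something is new, unique, unknown or untested is made for them only; others in the source may bear on it.

Measured compounds so far:
- compound 1, `O=[N+]([O-])c1cccc(-c2nn(-c3ccccc3)cc2C(Nc2nc3ccccc3s2)c2c(O)ccc3ccccc23)c1`, 8220 nM
- compound 2, `Oc1ccc2ccccc2c1C(Nc1nc2ccccc2s1)c1cn(-c2ccccc2)nc1-c1cccc(Cl)c1`, 6830 nM
- compound 3, `COc1ccc2nc(NC(c3cn(-c4ccccc4)nc3-c3ccc(Cl)cc3)c3c(O)ccc4ccccc34)sc2c1`, 5200 nM

All three were run in a functional assay on HeLa cells (Homo sapiens) for antiproliferative activity, read by MTT assay, with a stated time of 48 h; on this read-out lower numbers stand for stronger inhibition and higher numbers for weaker inhibition. Compound 1 gives 8220 nM, compound 2 gives 6830 nM and compound 3 gives 5200 nM. The step of a 1.2-fold higher number from compound 2 to compound 1 (0.08 log units; within the scatter) is within the scatter, so compounds 1 and 2 cannot be told apart on this read-out. Compound 3 has the lowest of the three numbers, but its gaps to compound 2 and to compound 1 are also within the scatter, so no ordering is claimed. The difference between the core of compound 2 and the core of compound 3 is not broken down here.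

Compound 4, `COc1ccc2nc(NC(c3cn(-c4ccccc4)nc3-c3ccc([N+](=O)[O-])cc3)c3c(O)ccc4ccccc34)sc2c1`, has not yet been measured in this assay. It is made from compound 3 by nitro in place of chloro on an aromatic carbon. The earlier pair, compound 2 to compound 1, carries nitro in place of chloro on an aromatic carbon. The two places differ in their printed wording: meta to a large group in the earlier pair, para to a large group in the new one, so the change is the same kind of change, not the same. Because the earlier step of a 1.2-fold higher number from compound 2 to compound 1 (0.08 log units; within the scatter) stayed within the scatter, compound 4 is expected to sit close to compound 3, with an estimated step of a 1.2-fold higher number from compound 3 to compound 4 (0.08 log units; within the scatter). The estimate for compound 4 is 6300 nM, expected to lie between 3200 nM and 12500 nM.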

Compound 4, half-maximal inhibitory concentration: 5540 nM
The estimate for compound 4 lay 1.1-fold (0.06 log units) above the measured number; measured number inside the range.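

In this assay, nitro in place of chloro, read here as 4-chlorophenyl to 4-nitrophenyl, gives a 1.1-fold higher number from compound 3 to compound 4 (0.03 log units; within the scatter), so the two compounds cannot be told apart on this read-out. The step on this core agrees with the earlier one: the same change on two cores in this assay, a 1.2-fold higher number (0.08 log units; within the scatter) from compound 2 to compound 1 and a 1.1-fold higher number (0.03 log units; within the scatter) from compound 3 to compound 4, 1.1-fold (0.05 log units) apart, within the scatter of two such steps. For the compounds shown here, this shows that the change carried from one core to the other without a step that can be told from the scatter, but with only two pairs in one cell line, it does not show that nitro and chloro are interchangeable on other cores or in other read-outs, and the core and the place of the group vary together across the pairs, so their contributions cannot be separated.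

Open, from the compounds shown here alone, is whether a group of another kind on the same phenyl ring, such as an amine, a carboxylic acid or a longer alkyl chain, would give a step beyond the scatter on either core. Also open, going by these compounds, is whether nitro in place of chloro would stay within the scatter on a core whose number lies far from the range seen for these four compounds.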